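The source may hold more compounds than are shown below. What is called first, only, known or untested is meant among the compounds shown, and "the series" means these compounds.

Compound 3 `CC(C)C[C@H](NC(=O)CC[C@H](NC(=O)[C@H](CC(C)C)NC(=O)OC(C)(C)C)C(=O)NCc1ccc2ccccc2c1)B(O)O` is the only one of the three measured compounds to give a number in a functional assay on HeLa cells (Homo sapiens) for inhibition, read by MTT assay, with a stated time of 72 h; a lower number here means a stronger inhibitor, a higher number a weaker inhibitor: compound 3 gives 790 nM. Compound 1 `CC(C)C[C@H](NC(=O)CC[C@H](NC(=O)OC(C)(C)C)C(=O)NCc1ccc2ccccc2c1)B(O)O` stops at the limit of this assay, giving > 10000 nM. Compound 2 `CC(C)C[C@H](NC(=O)C[C@H](NC(=O)OC(C)(C)C)C(=O)NCc1ccc2ccccc2c1)B(O)O` also stops at the limit of this assay, with > 10000 nM. The step that the two limits leave unreadable from compound 1 to compound 2 is therefore of unknown size, because both of its ends sit at the limit of > 10000 nM in this assay, at which 2 of the 3 values shown sit.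

Compound 4 `CC(C)C[C@H](NC(=O)CC[C@H](NC(=O)CNC(=O)OC(C)(C)C)C(=O)NCc1ccc2ccccc2c1)B(O)O` differs from compound 3 in a single place: hydrogen in place of isobutyl on a saturated chain carbon bound to an amide-type nitrogen and a carbonyl carbon. No measured step covers a change of this kind, so nothing shown sets its size directly. Compound 1 carries no isobutyl-bearing group at that end of the chain and remains at the limit. Compound 3, which carries the isobutyl, gives a readable number. Taking the isobutyl away in compound 4 while keeping the rest of the chain is thus expected to cost some potency, though less than the full gap between compound 1 and compound 3 might suggest; the expected step is a 3.8-fold higher number from compound 3 to compound 4 (0.58 log units; beyond the scatter). For compound 4 the estimate in this assay is 3000 nM, within a range of 800 nM to 12000 nM.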

Compound 4, half-maximal inhibitory concentration: 350 nM
Estimate against measurement, compound 4: 8.6-fold (0.93 log units) above; measured number below the stated range.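

Taking the isobutyl away does not cost potency in this assay. Hydrogen in place of isobutyl on a saturated chain carbon bound to an amide-type nitrogen and a carbonyl carbon gives a 2.3-fold lower number from compound 3 to compound 4 (0.35 log units; beyond the scatter), so compound 4 is the stronger of this pair and the isobutyl is not needed for a readable number in these cells. The larger change lies at the end of the chain, where ((tert-butoxycarbonyl)amino)methyl in place of tert-butoxy on a carbonyl carbon gives an at least 28-fold lower number from compound 1 to compound 4 (1.45 log units; beyond the scatter), although compound 1 stands at a limit, so that step has a smallest size and no exact one: the limit of > 10000 nM in this assay, at which 2 of the 4 values shown sit.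

The compounds shown leave open whether hydrogen is the best choice on this carbon, or whether a methyl, a hydroxymethyl or a chain ending in an amine or a carboxylic acid would give a lower or a higher number than compound 4. They also leave open whether the same end group, with hydrogen on this carbon, would give a readable number on the shorter chain of compound 2.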